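Thiophen-2-yl for Phenyl on a Nucleoside Core

The compounds below may be only part of what the source reports. "The series", "measured", "known", "first", "only" and "open" are said of these compounds alone.

The account follows three nucleoside analogues tested in a functional assay on HCT-116 cells (Homo sapiens), read by MTT assay, with a stated time of 72 h (on this read-out lower numbers stand for stronger inhibition and higher numbers for weaker inhibition), and asks what a fourth might do. Compound 1 `Nc1nc2c(c(-c3ccccc3)cn2[C@@H]2O[C@H](CO)[C@@H](O)[C@H]2O)c(=O)[nH]1` is the reference. In this assay compound 1 reaches only the limit of the measurement, > 20000 nM, and no number. Compound 2 `CNc1ncnc2c1c(-c1ccoc1)cn2[C@@H]1O[C@H](CO)[C@@H](O)[C@H]1O` likewise stops at the limit, giving > 20000 nM in this assay. Compound 3 `Cc1nc(N)c2c(-c3ccsc3)cn([C@@H]3O[C@H](CO)[C@@H](O)[C@H]3O)c2n1` gives > 20000 nM in this assay, again a limit rather than a number. Compound 1 therefore stands nowhere in particular among the numbers shown, because all three sit at the limit of > 20000 nM in this assay, at which 3 of the 3 values shown sit.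

Compound 4 `Nc1nc2c(c(-c3cccs3)cn2[C@@H]2O[C@H](CO)[C@@H](O)[C@H]2O)c(=O)[nH]1` is not yet measured. It differs from compound 1 in one place: thiophen-2-yl in place of phenyl on an aromatic carbon. Among the compounds with values here, no step between measured compounds is available to guide the expectation, and nothing among the three measured compounds points away from the limit. The expected step from compound 1 to compound 4 in this assay is a step that the limit leaves unreadable from compound 1 to compound 4, that is, none beyond the scatter. Compound 4 is estimated to give 25000 nM in this assay, within a range of 8000 nM to 80000 nM, most likely reported again as a limit.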

Compound 4, half-maximal inhibitory concentration: 19800 nM
Beside the measured number, compound 4's estimate is 1.3-fold (0.10 log units) above it; the measured number falls inside the stated range.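

In this assay compound 4 gives 19800 nM, the only number among the compounds shown, so thiophen-2-yl on this aromatic carbon of the shared core returns a readable value. For compound 1, > 20000 nM is a limit and not a number. The step reads a number no higher from compound 1 to compound 4 (the limit leaves the size open) and puts thiophen-2-yl in place of phenyl on an aromatic carbon. The change from phenyl to thiophen-2-yl therefore has no readable size, because the reference compound stands at the limit: the limit of > 20000 nM in this assay, at which 3 of the 4 values shown sit.

Compounds 2 and 3 differ from compound 4 in more than one place, so they do not show how much of its readable value belongs to thiophen-2-yl and how much to the core of compound 4. Going by these compounds, it remains open whether furan-2-yl, a pyridine ring or a plain methyl group at this position on the same core would also give a number.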